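A few compounds are considered here, and "the series" means these few. Any claim that something is new, unique, unknown or untested is made for them only; others in the source may bear on it.

Compound 3, `CCC(C)N(Cc1cccs1)C(=O)COc1ccc(C)cc1`, is one of three compounds examined for agonist activity in an assay on HEK293 cells for agonist activity at transient receptor potential cation channel subfamily M member 8 (Homo sapiens), read by fluorescence and calcium flux, with a stated time of 15 min; on this read-out lower numbers stand for an effect already at smaller amounts and higher numbers for an effect only at larger amounts of compound. There compound 3 gives 2000 nM, the higher of the two numbers recorded. Compound 1, `CCN(Cc1ccoc1)C(=O)COc1ccc(C)cc1`, gives 136 nM in this assay, a number lower than that of compound 3 by a gap well beyond the scatter. Compound 2, `CCN(Cc1cccs1)C(=O)C[C@@H](O)c1ccccc1`, gives "not active" (no number reported) in this assay, with no number reported.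

The next compound, compound 4, `Cc1ccc(OCC(=O)N(Cc2cccs2)c2cnn(C)c2)cc1`, differs from compound 3 in one place: 1-methyl-1H-pyrazol-4-yl in place of sec-butyl on an amide-type nitrogen. Among the measured compounds shown here, no pair of measured compounds shows this change on its own, so the size of the step it brings has to be estimated. Compound 1 shows that a lower number than that of compound 3 is attainable within this set, but its structure differs from compound 3 in more than one place and offers no direct guide. The expectation is a modest move toward a lower number, a 2.5-fold lower number from compound 3 to compound 4 (0.40 log units; beyond the scatter), carrying wide uncertainty. For compound 4 the estimate in this assay is 800 nM, with a range from 150 nM to 4000 nM.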

Compound 4, half-maximal effective concentration: 63000 nM
Compound 4: middle estimate off by 79-fold (1.90 log units), on the low side; measured number above the stated range.
By their numbers in this assay, from the lowest: compound 1; then compound 3; then compound 4.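

Among the compounds shown here, on the amide-type nitrogen, the exchange of sec-butyl for 1-methyl-1H-pyrazol-4-yl gives the first reading of a single change in this set: in this assay it brings a 32-fold higher number from compound 3 to compound 4 (1.50 log units; beyond the scatter) and thus a large step beyond the usual scatter. The earlier compounds shown here differ from one another in more than one place, so they could not show that this one position can move the number so far, or in this direction. The data offered here give no reason for the size of the step.

The compounds shown leave open whether the higher number goes with the aromatic ring, its two nitrogens or its methyl group, a question that a cyclopentyl or an unsubstituted pyrazolyl group on the same nitrogen would address. They also leave open whether an ethyl or a longer chain there would give a number different from that of compound 3.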